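Hydroxy for Amino on a Side Chain: Lipophilicity Expected to Rise

A few compounds are considered here, and "the series" means these few. Any claim that something is new, unique, unknown or untested is made for them only; others in the source may bear on it.

Measured compounds:
compound 1 `CC(C)(CN)C(=O)N1N=CCC1c1ccccc1`: 1.4
compound 2 `N#Cc1cc(N2CCC(C(=O)N3N=CC[C@H]3c3cc(F)cc(F)c3)CC2)ncn1`: 5
compound 3 `O=C(C1CCN(c2ccccc2)CC1)N1N=CCC1c1ccccc1`: 6.3

In a physicochemical assay for lipophilicity, read by HPLC, measured as chromatographic lipophilicity, at pH 7.4 (a higher number here means a more lipophilic compound, a lower number a more polar compound), compound 1 gives 1.4, the lowest of the three numbers; compound 2 gives 5 and compound 3 gives 6.3, both beyond the scatter above it. The unmeasured compound 4 `CC(C)(CO)C(=O)N1N=CCC1c1ccccc1` differs from compound 1 in one place: hydroxy in place of amino on a saturated chain carbon, two bonds along the chain from a carbonyl carbon. For the measured compounds named here, no measured pair shows this change, so the size of its step is not known from these data. The expectation is a step upward beyond the scatter, of moderate size, in this assay. For compound 4 the expected value is 2.6, within a range from 1.8 to 3.4, an estimated step of a number 1.20 log units higher from compound 1 to compound 4 (beyond the scatter).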

Compound 4, distribution coefficient: 3.4
For compound 4 the middle estimate is 0.80 log units below the measured one; low and high end bracket the measured number.
By their numbers in this assay, from the lowest: compound 1; then compound 4; then compound 2; then compound 3.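

In this assay, for the compounds shown here, hydroxy in place of amino on a saturated chain carbon, two bonds along the chain from a carbonyl carbon, gives the first measured step for this change: a number 2.00 log units higher from compound 1 to compound 4 (beyond the scatter), a large one. Amino and hydroxy match in heavy atoms, hydrogen-bond donors, hydrogen-bond acceptors and net charge, so those counts alone do not set the size of this step. No supporting measurement gives a reason for it. On these data alone, whether a methoxy group or a carboxylic acid at this place would shift the number as far stays open. So does whether the same step appears on a longer chain or another core.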